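The source may report more compounds than this note shows. Statements on the series, on what has been measured and on what is new or still open speak of the compounds shown alone.

Measured so far:

compound 1, `COc1cc(C)cc(-c2c(-c3ccnc(-c4ccc(N(C)C)cc4)c3)cnn2CC#N)c1`: -59%
compound 2, `COc1cc(C)cc(-c2nn(CC#N)cc2-c2ccnc(-c3ccc(N(C)C)cc3)c2)c1`: -63%
compound 3, `COc1cc(C)cc(-c2nn(CC#N)cc2-c2ccc(-c3cccc(C(C)=O)c3)nc2)c1`: -53%

All three numbers come from a functional assay on MDA-MB-468 cells (Homo sapiens) for cytotoxicity, read by sulforhodamine B assay, with a stated time of 48 h, tested at 10 uM; a higher number here means a weaker effect of the compound at the concentration tested, a lower number a stronger effect. Compound 2 gives the smallest number of the three, yet its gaps to compound 1 and to compound 3 both fall within the usual scatter of repeated measurements, so the three compounds cannot be told apart on these numbers alone.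

The next compound, compound 4, `Cc1cc(O)cc(-c2nn(CC#N)cc2-c2ccnc(-c3ccc(N(C)C)cc3)c2)c1`, is built from compound 2 by a single small change: hydrogen in place of methyl on an oxygen on an aromatic ring. Put another way, the methoxy group of compound 2 becomes a hydroxy group, so the 3-methoxy-5-methylphenyl ring turns into a 3-hydroxy-5-methylphenyl ring; everything else in the molecule stays the same.

Among the compounds with values here, no pair of measured compounds shows this change, so there is no direct precedent for its effect in this assay. With only the three numbers above to go on, the step is expected to be small, most likely none beyond the scatter, with a slight lean towards a weaker effect. The step from compound 2 to compound 4 is therefore estimated as a number 11 percentage points higher from compound 2 to compound 4 (beyond the scatter). For compound 4 the expected result in this assay is -52%, with a likely range from -80% to -20%.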

Compound 4, a percentage reported as activity, at one concentration (the size of the read-out at that concentration, not a potency): -61%
Compound 4: the middle estimate sits 9 percentage points above what was measured, within the range that was stated.
By their numbers in this assay, from the lowest: compounds 2, 4, 1 and 3 (each within the scatter of the next).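

In this assay, within the data shown here, replacing the methyl on the oxygen with hydrogen gives a number 2 percentage points higher from compound 2 to compound 4 (within the scatter), the first direct comparison at this place on the aromatic ring. The earlier compounds shown here all carry the methoxy group, so they could not show what happens when it becomes a hydroxy group; this pair shows that, at the single concentration tested, the 3-methoxy-5-methylphenyl and 3-hydroxy-5-methylphenyl versions cannot be told apart. No measurement at hand offers an explanation for this result.

On these data alone, only methoxy and hydroxy appear on this ring position, so it remains open whether a longer chain on the oxygen, such as ethoxy or butoxy, or an amine in place of the hydroxy group, would also leave the read-out within the scatter. Each number is the size of the effect at one concentration rather than a potency. Compound 2 and compound 4 could still differ at lower concentrations, and this single pair says nothing about the same change on a different core.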